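Benzyl substituent exchange in a macrophage cytotoxicity series

The source may report more compounds than this note shows. Statements on the series, on what has been measured and on what is new or still open speak of the compounds shown alone.

Measured so far:
compound 1 `CC1(Cc2cccc(C(F)(F)F)c2)CC(S(=O)(=O)c2ccc(F)cc2)=C(c2ccc(/C(N)=N/O)cc2)O1`: in an ADME assay on cells (Peritoneal macrophage, Mus musculus, strain Balb/c) for cytotoxicity, read by resazurin assay, with a stated time of 72 h (on this read-out lower numbers stand for higher toxicity in this test and higher numbers for lower toxicity in this test), compound 1 gives 49800 nM
compound 2 `CC1(Cc2ccc([N+](=O)[O-])cc2)CC(S(=O)(=O)c2ccc(F)cc2)=C(c2ccc(/C(N)=N/O)cc2)O1`: compound 2 gives 97400 nM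
compound 3 `COc1ccc(CC2(C)CC(S(=O)(=O)c3ccc(F)cc3)=C(c3ccc(/C(N)=N/O)cc3)O2)cc1`: compound 3 gives > 100000 nM, which is a limit of the assay and not a number

Compound 1 holds the lowest of the two numbers in the series. The step to compound 2 is a 2.0-fold higher number from compound 1 to compound 2 (0.29 log units; within the scatter). Compound 3 reaches only the limit described by the limit of > 100000 nM in this assay, at which 1 of the 3 values shown sits, so its step from compound 1 reads an at least 2.0-fold higher number from compound 1 to compound 3 (0.30 log units; that floor lies within the scatter).

Compound 4 `CC1(Cc2ccc(CO)cc2)CC(S(=O)(=O)c2ccc(F)cc2)=C(c2ccc(/C(N)=N/O)cc2)O1` awaits measurement in this assay. It differs from compound 1 in one place: 4-(hydroxymethyl)phenyl in place of 3-(trifluoromethyl)phenyl on a saturated chain carbon bound to a saturated ring carbon. Going by the values given here, the steps that bear on it are the two other exchanges at the same place, from compound 1 to compound 2 and from compound 1 to compound 3. Both stay within the scatter at their floor, and neither moved the number downward. For compound 4 a step of a 1.8-fold higher number from compound 1 to compound 4 (0.26 log units; within the scatter) is therefore expected, toward a higher number, with a real chance that only the limit is reported. The expected value for compound 4 is 90000 nM, in the range 40000 nM to 200000 nM.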

Compound 4, half-maximal cytotoxic concentration: > 100000 nM
Compound 4 was reported as a limit (the forecaster's own chance of this, stated with the estimate: 45%); middle value at least 1.1-fold (0.04 log units) away from the limit.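

In this assay compound 4 is reported only as a limit of the assay and not as a number, and the series now holds a second such value: the limit of > 100000 nM in this assay, at which 2 of the 4 values shown sit.

The exchange from the trifluoromethyl group gives an at least 2.0-fold higher number from compound 1 to compound 4 (0.30 log units; that floor lies within the scatter), and the exchange from the nitro group gives an at least 1.0-fold higher number from compound 2 to compound 4 (0.01 log units; that floor lies within the scatter), so neither floor separates compound 4 from the compound it is compared with. What is new is that a group with a hydrogen-bond donor, 4-(hydroxymethyl)phenyl, now stands at this place, on a saturated chain carbon bound to a saturated ring carbon, and no step beyond the scatter appears.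

The step between compound 3 and compound 4 cannot be read, as both values are limits. Open, on these data alone, is whether a benzyl group carrying an amine or a carboxylic acid would give a step beyond the scatter.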